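The source may report more compounds than this note shows. Statements on the series, on what has been measured and on what is new or still open speak of the compounds shown alone.

Measured so far in an assay on membranes from cerebellum for inhibition of Fatty-acid amide hydrolase 1 (Rattus norvegicus); a higher number here means a weaker inhibitor, a lower number a stronger inhibitor:
compound 1 `O=C(OCC1CCCCO1)c1ccc(-c2ccccc2)cc1`: 32000 nM
compound 2 `CCCCC/C=C\C/C=C\C/C=C\C/C=C\CCCC(=O)OC[C@@H]1COC(C)(C)O1`: 17000 nM
compound 3 `O=C(OCC1CCCCO1)c1cccc(-c2ccccc2)c1`: 18000 nM

On these numbers compound 2 cannot be separated from the others: compound 3 and compound 1 both sit within the usual scatter of compound 2, so no order among the three can be read. Among the measured compounds shown here, no step between two measured compounds that differ in one place is available.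

Compound 4 `CCCCC/C=C\C/C=C\C/C=C\C/C=C\CCCC(=O)OC[C@H]1COC(C)(C)O1` is the next candidate. It differs from compound 2 as follows: the two compounds have the same atoms and bonds and differ only in configuration as drawn: 1 of 5 stereo elements differ; a stereocentre at a saturated ring carbon is drawn S in compound 2 and R in compound 4. For the measured compounds named here, with no measured pair of this kind, the step from compound 2 to compound 4 is expected to stay within the scatter, in either direction: no change at the digits printed from compound 2 to compound 4 (within the scatter). For compound 4 in this assay the estimated value is 17000 nM, expected between 6000 nM and 50000 nM.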

Compound 4, half-maximal inhibitory concentration: 28000 nM
The estimate for compound 4 lay 1.6-fold (0.22 log units) below the measured number; low and high end bracket the measured number.
By their numbers in this assay, from the lowest: compounds 2, 3, 4 and 1 (each within the scatter of the next).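

In this assay, the series now has its first comparison at a single place, the stereocentre at a saturated ring carbon, and inverting it from S to R gives a 1.6-fold higher number from compound 2 to compound 4 (0.22 log units; within the scatter). This is the only structural difference behind that step: the fact that compounds 2 and 4 differ only in the configuration as drawn. At this position, the change of configuration therefore gives no readable difference, so neither form can be preferred.

Still open, from the compounds shown here alone, is whether a carbamate or an amide in place of the ester would move the number beyond the scatter. Also open, going by these compounds, is whether a shorter chain on the acyl side would do so.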